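Swapping fluoro for methoxy on the aryl piperazine

A few compounds are considered here, and "the series" means these few. Any claim that something is new, unique, unknown or untested is made for them only; others in the source may bear on it.

Of the compounds shown here, three sharing one core have been tested in a functional assay on SK-N-SH cells (Homo sapiens) for inhibition, read by MTT assay; on this read-out higher numbers stand for weaker inhibition and lower numbers for stronger inhibition. Compound 1 `CCCCCCCCn1cc(/C=C/C(=O)c2ccc(NC(=O)CN3CCN(c4ccccc4F)CC3)cc2)nn1` gives 60300 nM. Compound 2 `O=C(CN1CCN(c2ccccc2F)CC1)Nc1ccc(C(=O)/C=C/c2cn(Cc3ccc(Br)cc3)nn2)cc1` gives 12800 nM, and compound 3 `CCCCCCCCn1cc(/C=C/C(=O)c2ccc(NC(=O)CN3CCN(C(=O)OC(C)(C)C)CC3)cc2)nn1` gives 38000 nM. Compound 2 stands lowest of the three: it is reached through a 4.7-fold lower number from compound 1 to compound 2 (0.67 log units; beyond the scatter), and compound 3 sits at a higher number than compound 2.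

Compound 4 `COc1ccccc1N1CCN(CC(=O)Nc2ccc(C(=O)/C=C/c3cn(Cc4ccc(Br)cc4)nn3)cc2)CC1` has not yet been measured. It differs from compound 2 by methoxy in place of fluoro on an aromatic carbon. The measured step that bears on this part of the molecule is a 1.6-fold lower number from compound 1 to compound 3 (0.20 log units; within the scatter), where a far larger exchange on the same amine nitrogen in the ring left the number within the scatter. The other step, a 4.7-fold lower number from compound 1 to compound 2 (0.67 log units; beyond the scatter), concerns the opposite end of the core and says nothing about this position. A small exchange at a tolerant position is therefore expected to give no step beyond the scatter, and the expected step is a 1.0-fold higher number from compound 2 to compound 4 (0.01 log units; within the scatter). Compound 4 is estimated at 13000 nM, with a range from 5000 nM to 35000 nM.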

Compound 4, half-maximal inhibitory concentration: 28000 nM
The estimate for compound 4 lay 2.2-fold (0.33 log units) below the measured number, and the stated range covers the measured number.
By their numbers in this assay, from the lowest: compound 2; then compounds 4, 3 and 1 (each within the scatter of the next, the first and the last beyond it).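

In this assay, the change from 2-fluorophenyl to 2-methoxyphenyl gives a 2.2-fold higher number from compound 2 to compound 4 (0.34 log units; beyond the scatter), so a small exchange at this place on the aromatic ring does move the number, though only modestly, and towards weaker inhibition. The earlier step, a 1.6-fold lower number from compound 1 to compound 3 (0.20 log units; within the scatter), replaced the whole aryl group in a compound with a different chain at the other end, so it could not show how a single group on this ring reads out. Methoxy is the larger of the two groups and counts as a hydrogen-bond acceptor where fluoro does not, but nothing available connects either feature to the higher number.

On these data alone, it remains open whether the same exchange would give a similar step with the chain of compound 1 at the other end of the core. As far as these compounds go, it is also open how chloro, hydroxy or ethoxy would read at this place on the ring.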